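The compounds below may be only part of what the source reports. "The series", "measured", "known", "first", "only" and "open" are said of these compounds alone.

Measured compounds:
- compound 1, `COc1cc(/C=N/Nc2nc(-c3ccc(C(F)(F)F)cc3)cs2)c(Br)c(Br)c1OC`: in an ADME assay on HUVEC cells (Homo sapiens) for inhibition, read by MTT assay, with a stated time of 48 h (on this read-out lower numbers stand for stronger inhibition and higher numbers for weaker inhibition), compound 1 gives > 100000 nM, which is a limit of the assay and not a number.
- compound 2, `Fc1ccc(/C=N/Nc2nc(-c3ccc(F)c(F)c3)cs2)cc1F`: in this assay compound 2 gives 59700 nM.
- compound 3, `COc1ccccc1-c1csc(N/N=C/c2ccc(F)c(F)c2)n1`: in this assay compound 3 gives > 100000 nM, again a limit of the assay.

Compound 1 thus stands at the ceiling of the series: its entry is a limit, and the same holds for (the limit of > 100000 nM in this assay, at which 2 of the 3 values shown sit). Among the measured compounds shown here, the only numbered value belongs to compound 2. For the measured compounds named here, the single measured step, an at least 1.6-fold higher number from compound 2 to compound 3 (0.22 log units; that floor lies within the scatter), concerns a change of the aryl group on the shared core and runs from a number to a limit.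

Compound 4, `COc1cc(/C=N/Nc2nc(-c3ccc(Br)cc3)cs2)c(Br)c(Br)c1OC`, differs from compound 1 by bromo in place of trifluoromethyl on an aromatic carbon. Going by the values given here, none of the measured steps involves this change. The step from compound 2 to compound 3 alters a different group, so it does not bear on the exchange of trifluoromethyl for bromo. Among the compounds with values here, with compound 1 already at a limit and no measured step touching the trifluoromethyl group, no movement beyond the scatter is expected. The step of a number no higher from compound 1 to compound 4 (the limit leaves the size open) is therefore expected to sit within the scatter. Compound 4 is expected to come out at 100000 nM, with a range of 40000 nM to 300000 nM, and most likely again reported only as a limit.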

Compound 4, half-maximal inhibitory concentration: > 100000 nM
Compound 4: a limit, no number; the forecaster's own chance of this, stated with the estimate: 70%; the middle value sits exactly at the limit.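

The step from compound 1 to compound 4, bromo in place of trifluoromethyl, cannot be read, as both entries are limits of the assay and not numbers: the limit of > 100000 nM in this assay, at which 3 of the 4 values shown sit.

The compounds shown leave open whether this exchange changes the read-out in this assay at all, and how far either compound lies beyond its limit.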